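One Terminal Ring Swap from Compound 1 to Compound 3

A few compounds are considered here, and "the series" means these few. Any claim that something is new, unique, unknown or untested is made for them only; others in the source may bear on it.

Measured so far:
compound 1 `C=C/C=C\[C@H](C)[C@H](OC(N)=O)[C@@H](C)[C@H](O)[C@@H](C)C/C(C)=C\[C@H](C)[C@@H](O)[C@@H](C)/C=C\CCc1cccc(F)c1` — 400 nM in a functional assay on SK-OV-3 cells (Homo sapiens) for cytotoxicity; on this read-out lower numbers stand for stronger inhibition and higher numbers for weaker inhibition
compound 2 `C=C/C=C\[C@H](C)[C@H](OC(N)=O)[C@@H](C)[C@H](O)[C@@H](C)C/C(C)=C\[C@H](C)[C@@H](O)[C@@H](C)/C=C\CCc1cccc(Cl)c1` — 380 nM in this assay

Compound 1 holds the higher of the two numbers, yet the step of a 1.1-fold lower number from compound 1 to compound 2 (0.02 log units; within the scatter) lies within the scatter, so neither compound can be ranked against the other. Compound 3 `C=C/C=C\[C@H](C)[C@H](OC(N)=O)[C@@H](C)[C@H](O)[C@@H](C)C/C(C)=C\[C@H](C)[C@@H](O)[C@@H](C)/C=C\CCc1sccc1C` differs from compound 1 by 3-methylthiophen-2-yl in place of 3-fluorophenyl on a saturated chain carbon, two bonds along the chain from a double-bonded chain carbon. Within the data shown here, the one measured step concerns a different change on the same ring and stayed within the scatter; no measured step bears directly on a ring-for-ring swap. A small shift in this assay, in either direction or none beyond the scatter, is therefore expected. Compound 3 is estimated at 450 nM, between 150 nM and 1300 nM. The expected step is a 1.1-fold higher number from compound 1 to compound 3 (0.05 log units; within the scatter).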

Compound 3, half-maximal inhibitory concentration: 370 nM
Estimate against measurement, compound 3: 1.2-fold (0.09 log units) above; the range from low to high includes it.
By their numbers in this assay, from the lowest: compounds 3, 2 and 1 (each within the scatter of the next).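

The ring swap gives a 1.1-fold lower number from compound 1 to compound 3 (0.03 log units; within the scatter) and a 1.0-fold lower number from compound 2 to compound 3 (0.01 log units; within the scatter) in this assay for this ring at the end of the chain. The earlier pair varied only a halogen on a phenyl ring, whereas this position now also carries a five-membered aromatic ring with sulfur and a methyl group, and all three compounds stay within the scatter of one another. No supporting data bear on this result. The compounds shown leave open whether an amine or a carboxylic acid in place of this ring, or a longer chain leading to it, would give a step beyond the scatter.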